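The source may hold more compounds than are shown below. What is called first, only, known or untested is meant among the compounds shown, and "the series" means these compounds.

Measured in an ADME assay on MDCK cells (Canis lupus familiaris) for cytotoxicity, read by MTT assay, with a stated time of 24 h; a higher number here means that more compound is tolerated, a lower number that less compound is tolerated:
Compound 1 `N#CCCN(Cc1cccs1)S(=O)(=O)c1ccc(Br)cc1`: > 173000 nM, a limit
Compound 2 `N#CCCN(Cc1cccs1)S(=O)(=O)c1ccc([N+](=O)[O-])cc1`: > 189000 nM, a limit
Compound 3 `O=S(=O)(c1ccc(Br)cc1)N(Cc1cccs1)Cc1cccs1`: 81000 nM

Within the data shown here, compound 3 holds the only true number of the three, since the other two values are limits. Compound 4 `CCCN(Cc1cccs1)S(=O)(=O)c1ccc(Br)cc1`, not yet measured, carries ethyl in place of thiophen-2-yl on a saturated chain carbon bound to a sulfonamide nitrogen. The bearing step is an at least 2.1-fold lower number from compound 1 to compound 3 (0.32 log units; beyond the scatter), where thiophen-2-yl entered at that same place. The step that the two limits leave unreadable from compound 1 to compound 2 concerns an aromatic carbon and does not bear on this change. With thiophen-2-yl leaving again, a modest rise in this assay is expected. The estimated step is a 2.1-fold higher number from compound 3 to compound 4 (0.32 log units; beyond the scatter). For compound 4 the expected value is 170000 nM, with an estimated range of 90000 nM to 320000 nM.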

Compound 4, half-maximal cytotoxic concentration: > 178000 nM
Compound 4 ended at the assay's limit; the forecaster's own chance of this, stated with the estimate: 50%; middle value at least 1.0-fold (0.01 log units) away from the limit.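

In this assay, ethyl in place of thiophen-2-yl gives an at least 2.1-fold higher number from compound 3 to compound 4 (0.34 log units; beyond the scatter), so the lower number of compound 3 now appears against two neighbours at this place, not only against the nitrile-bearing compound 1. Compound 4 carries no nitrile and still ends at a limit, so the nitrile is not needed for that outcome. The step between compound 1 and compound 4 cannot be read, as both values are limits.

From the compounds shown here alone, it remains open whether the lower number is specific to thiophen-2-yl or would also follow from a longer chain or an amine at this place. Going by these compounds, how far compound 4 actually lies past its limit also remains open.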